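This account rests on a few compounds, and the source may have more. Where it says the series, first, only, none or still open, it means among the compounds named here.

Measured so far in this study:
compound 1, `CC1CCN(c2c(S(=O)(=O)c3cccc(F)c3)cnc3ccc(F)cc23)CC1`, 76%
compound 2, `CC1CCN(c2c(S(=O)(=O)c3cccc(Cl)c3)cnc3cc(Cl)ccc23)CC1`, 92%
compound 3, `COCC1CCN(c2c(S(=O)(=O)c3cccc(F)c3)cnc3cc(F)ccc23)CC1`, 70.5%

In an assay on isolated protein for displacement of a labelled ligand from metabotropic glutamate receptor 5 (Homo sapiens), with a stated time of 60 min, tested at 1 uM (a lower number here means less inhibition, a higher number more inhibition at the concentration tested (going by the name of the read-out)), compound 2 gives 92%, the highest of the three numbers. Compound 1 gives 76%, a gap beyond the usual scatter, and compound 3 gives 70.5%, a still wider gap, also beyond the scatter. Compound 4, `CC1CCN(c2c(S(=O)(=O)c3ccc(F)c(Cl)c3)cnc3cc(Cl)ccc23)CC1`, has not been measured. It differs from compound 2 in one place: fluoro in place of hydrogen on an aromatic carbon. Among the measured compounds shown here, no pair of measured compounds shows this change, so the data give no direct reading of its size. With compound 2 already near the top of the scale, the expected step is a number 4 percentage points lower from compound 2 to compound 4 (within the scatter), likely no larger than the scatter and, if anything, slightly downward. Compound 4 is therefore estimated at 88%, with a range from 74% to 97%.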

Compound 4, a percentage reported as inhibition, at one concentration (the size of the read-out at that concentration, not a potency): 94%
Compound 4: middle estimate off by 6 percentage points, on the low side; measured number inside the range.
By their numbers in this assay, from the lowest: compounds 3 and 1 (each within the scatter of the next); then compounds 2 and 4 (each within the scatter of the next).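

In this assay, among the compounds shown here, the change from 3-chlorophenyl to 3-chloro-4-fluorophenyl gives a number 2 percentage points higher from compound 2 to compound 4 (within the scatter) and is the first reading of this change, so a fluoro group at this place, ortho to a chloro group and para to a large group, costs nothing beyond the scatter. Both compounds stand near the top of the scale, so this single-concentration read-out separates them little. Nothing measured here accounts for the result.

As far as these compounds go, whether a methoxy group, a trifluoromethyl group or an amine at this place would keep the inhibition stays open. So does the size of the fluoro step on a compound further from the top of the scale.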